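Removing one hydroxymethyl from compound 2

The source may report more compounds than this note shows. Statements on the series, on what has been measured and on what is new or still open speak of the compounds shown alone.

Of the compounds shown here, two have been read so far in an ADME assay on cells (kidney, Cercopithecidae) for cytotoxicity; on this read-out higher numbers stand for weaker inhibition and lower numbers for stronger inhibition: compound 1 `NC(=S)c1cn(COC(CO)CO)c2ncnc(N)c12` and compound 2 `Nc1ncnc2c1ccn2C(CO)OC(CO)CO`. Compound 1 gives > 100000 nM, which is a limit of the assay and not a number. Compound 2 gives > 100000 nM, which is likewise a limit and not a number. Compound 2 therefore has no numeric standing, only a place at the same limit as compound 1.

Compound 3 `Nc1ncnc2c1ccn2COC(CO)CO` follows from compound 2 with hydrogen in place of hydroxymethyl on a saturated chain carbon bound to an aromatic nitrogen and an oxygen on a saturated carbon. Among the compounds with values here, no measured pair shows what a change of this kind does. The expectation rests only on compound 1 and compound 2 sharing (the limit of > 100000 nM in this assay, at which 2 of the 2 values shown sit). The expected step of a number no higher from compound 2 to compound 3 (the limit leaves the size open) is none beyond the scatter in this assay, with no direction favoured. For compound 3 the estimated half-maximal inhibitory concentration is 100000 nM, with an expected range from 30000 nM to 300000 nM, and the read-out may well be only a limit again.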

Compound 3, half-maximal inhibitory concentration: > 100000 nM
Compound 3 was reported as a limit; the forecaster's own chance of this, stated with the estimate: 85%; the middle value lies on the limit itself.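

In this assay compound 3, like compound 1 and compound 2, gives a limit and not a number, so no step among these three compounds can be read: the limit of > 100000 nM in this assay, at which 3 of the 3 values shown sit.

The compounds shown leave open whether hydrogen in place of hydroxymethyl changes this read-out at all, and how far each compound lies beyond the limit.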